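Dropping a Methyl on a Catechol Ether Sulfonylurea Series

This account rests on a few compounds, and the source may have more. Where it says the series, first, only, none or still open, it means among the compounds named here.

Of the compounds shown here, three have been tested in a functional assay on RS4-11 cells (Homo sapiens) for inhibition, read by CCK-8 assay, with a stated time of 48 h; on this read-out higher numbers stand for weaker inhibition and lower numbers for stronger inhibition. Compound 3 `Cc1ccc(-c2ccsc2S(=O)(=O)NCCNC(=O)Nc2cc(Cl)cc(Cl)c2)c(Oc2ccc(O)c(O)c2)c1` gives 5100 nM, and compound 1 `O=C(NCCNS(=O)(=O)c1sccc1-c1ccccc1Oc1ccc(O)c(O)c1)Nc1cc(Cl)cc(Cl)c1` gives 6200 nM. The change between them is hydrogen in place of methyl on an aromatic carbon, and the step it made is a 1.2-fold higher number from compound 3 to compound 1 (0.08 log units; within the scatter). Compound 2 `Cc1ccc(-c2ccsc2S(=O)(=O)NCCNC(=O)Nc2cc(C(F)(F)F)cc(C(F)(F)F)c2)c(Oc2ccc(O)c(O)c2)c1` rests on a core that differs from the shared core of compound 1 and compound 3, and the difference between the two cores is not broken down here. In this assay compound 2 gives 5600 nM. Compound 4 `O=C(NCCNS(=O)(=O)c1sccc1-c1ccccc1Oc1ccc(O)c(O)c1)Nc1cc(C(F)(F)F)cc(C(F)(F)F)c1` has not yet been measured; it differs from compound 2 by hydrogen in place of methyl on an aromatic carbon, the same change as from compound 3 to compound 1. The step expected from compound 2 to compound 4 is a 1.2-fold higher number from compound 2 to compound 4 (0.07 log units; within the scatter), because the earlier step was a 1.2-fold higher number from compound 3 to compound 1 (0.08 log units; within the scatter). Compound 4 is therefore estimated at 6600 nM, with a likely range from 3500 nM to 13000 nM.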

Compound 4, half-maximal inhibitory concentration: 4900 nM
Beside the measured number, compound 4's estimate is 1.3-fold (0.13 log units) above it; measured number inside the range.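

Putting hydrogen in place of the methyl gives a 1.1-fold lower number from compound 2 to compound 4 (0.06 log units; within the scatter) in this assay. Set beside the same change on the other core, the two steps agree within the scatter: the same change on two cores in this assay, a 1.2-fold higher number (0.08 log units; within the scatter) from compound 3 to compound 1 and a 1.1-fold lower number (0.06 log units; within the scatter) from compound 2 to compound 4, 1.4-fold (0.14 log units) apart, within the scatter of two such steps

This shows that, on these two cores, the change leaves no effect that can be told apart from the scatter, so carrying it across cores has changed little here; it does not show that the methyl is without effect on other cores, or that a very small effect is absent.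

What the compounds shown leave open is whether a larger change on that aromatic carbon, such as a methoxy group, an amine or a carboxylic acid, would give a step beyond the scatter. They also leave open how a longer chain in place of the methyl would behave.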